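Working notes: compound 4 from compound 3

The source may report more compounds than this note shows. Statements on the series, on what has been measured and on what is new or still open speak of the compounds shown alone.

Measured so far:
compound 1 `CC(C)N1CCN(Cc2csc(N)c2C(=O)c2ccc(Cl)cc2)CC1`: -1%
compound 2 `Nc1scc(CN2CCN(c3ccc(Cl)cc3Cl)CC2)c1C(=O)c1ccc(Cl)cc1`: 2%
compound 3 `Nc1scc(CN2CCN(c3ccc(Cl)c(C(F)(F)F)c3)CC2)c1C(=O)c1ccc(Cl)cc1`: -2.5%

In a functional assay on CHO cells with adenosine receptor A1 (Homo sapiens) as the target, read by cAMP accumulation and immunoassay, with a stated time of 6 min, tested at 0.01 uM (a higher number here means a weaker effect of the compound at the concentration tested, a lower number a stronger effect), compound 1 gives -1%, compound 2 gives 2% and compound 3 gives -2.5%. The three numbers sit within the scatter of one another. Compound 3 stands at one end of this narrow span: a number 1.5 percentage points lower from compound 1 to compound 3 (within the scatter) and a number 4.5 percentage points lower from compound 2 to compound 3 (within the scatter), neither of which counts as a real difference. Between compound 1 and compound 2 the picture is the same: a number 3 percentage points higher from compound 1 to compound 2 (within the scatter).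

Compound 4 `Nc1scc(CN2CCN(c3cccnc3)CC2)c1C(=O)c1ccc(Cl)cc1` has not yet been measured. It differs from compound 3 in one place: pyridin-3-yl in place of 4-chloro-3-(trifluoromethyl)phenyl on an amine nitrogen in a ring. All three measured steps change the group on the amine nitrogen in a ring, and every one of them stays within the scatter, whether the group is isopropyl, 2,4-dichlorophenyl or 4-chloro-3-(trifluoromethyl)phenyl. Among the measured compounds shown here, no measured step brings in pyridin-3-yl, so nothing shows how this particular group behaves. On the steps at hand, no step beyond the scatter is expected in this assay for compound 4, that is a number 2.5 percentage points higher from compound 3 to compound 4 (within the scatter). Compound 4 is therefore estimated at 0%, with a range from -8% to 8%.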

Compound 4, a percentage reported as activity, at one concentration (the size of the read-out at that concentration, not a potency): 3.2%
For compound 4 the middle estimate is 3.2 percentage points below the measured one, within the range that was stated.
By their numbers in this assay, from the lowest: compounds 3, 1, 2 and 4 (each within the scatter of the next).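

Pyridin-3-yl on the amine nitrogen in a ring brings an aromatic ring with a hetero atom and a hydrogen-bond acceptor to this position, which none of the earlier groups has, yet in this assay the read-out stays within the scatter against all three: (a number 5.7 percentage points higher from compound 3 to compound 4 (within the scatter)), (a number 1.2 percentage points higher from compound 2 to compound 4 (within the scatter)) and (a number 4.2 percentage points higher from compound 1 to compound 4 (within the scatter)). With fewer heavy atoms than 4-chloro-3-(trifluoromethyl)phenyl, the change also shows that a smaller aromatic ring with a hetero atom yields no step beyond the scatter at the single concentration tested, so across these four compounds neither the ring nitrogen nor the loss of the chlorine and trifluoromethyl groups separates from the isopropyl and halogenated phenyl cases. No measurement at hand offers an explanation for this flat result.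

The compounds shown leave open whether a carboxylic acid, a primary amine or a longer alkyl chain on this amine nitrogen would produce a step beyond the scatter. From the compounds shown here alone, all four compounds share the rest of the core, so the effect of replacing its chlorine with, for example, a methoxy group also remains open.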